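Swapping a Trifluoromethyl for a Methoxy on a Moved Core

This account rests on a few compounds, and the source may have more. Where it says the series, first, only, none or still open, it means among the compounds named here.

Compound 1 `O=C1C=COC(/C=C/c2ccc(C(F)(F)F)cc2)C1` and compound 3 `O=C1C=CCC(/C=C/c2ccc(C(F)(F)F)cc2)O1` are built from the same atoms joined differently; the difference between the two cores is not broken down here. In an ADME assay on HaCaT cells (Homo sapiens) for inhibition, read by sulforhodamine B assay, with a stated time of 48 h (on this read-out lower numbers stand for stronger inhibition of growth and higher numbers for weaker inhibition of growth), compound 1 gives 123 uM and compound 3 gives 69.7 uM, two numbers that lie within the usual scatter of each other. Compound 2 `COc1ccc(/C=C/C2CC(=O)C=CO2)cc1` keeps the core of compound 1 and differs from it only in one place: methoxy in place of trifluoromethyl on an aromatic carbon. In this assay compound 2 gives 145 uM, so the step of a 1.2-fold higher number from compound 1 to compound 2 (0.07 log units; within the scatter) is small enough to count as no real change.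

Compound 4 `COc1ccc(/C=C/C2CC=CC(=O)O2)cc1` applies the same change to the core of compound 3: methoxy in place of trifluoromethyl on an aromatic carbon. The place matches word for word, so this is the same change made a second time, now on a different core. The number for compound 4 in this assay is expected to sit close to that of compound 3, because a 1.2-fold higher number from compound 1 to compound 2 (0.07 log units; within the scatter) barely moved the result. The step expected for compound 4 is a 1.2-fold higher number from compound 3 to compound 4 (0.07 log units; within the scatter), and the estimate for compound 4 is 82 uM, between 45 uM and 150 uM.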

Compound 4, concentration for growth inhibition (reported as GI): 58.8 uM
Beside the measured number, compound 4's estimate is 1.4-fold (0.14 log units) above it; the range from low to high includes it.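

In this assay, methoxy in place of trifluoromethyl on the second core gives a 1.2-fold lower number from compound 3 to compound 4 (0.07 log units; within the scatter); on this result, the two compounds cannot be told apart. Set beside the earlier case, the swap gives the same picture on both cores, and the two steps do not differ in any readable way: the same change on two cores in this assay, a 1.2-fold higher number (0.07 log units; within the scatter) from compound 1 to compound 2 and a 1.2-fold lower number (0.07 log units; within the scatter) from compound 3 to compound 4, 1.4-fold (0.15 log units) apart, within the scatter of two such steps. This shows that, for these two pairs, the swap makes no measurable difference on either core, but two cores are too few to promise the same on a third, and the steps do not explain why these two groups can stand in for each other.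

The compounds shown carry only trifluoromethyl or methoxy on this aromatic carbon, which leaves open what an amine, a carboxylic acid or a longer chain such as butoxy would do there. Also open, from the compounds shown here alone, is whether the swap would stay this quiet in a different cell type or over a different exposure time.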